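The source may hold more compounds than are shown below. What is called first, only, known or untested is meant among the compounds shown, and "the series" means these compounds.

Measured compounds:
- Compound 1 `CC(C)c1ccc(NC(=O)N2CCN(c3ncccc3Cl)CC2)cc1`: in a functional assay on HEK293 cells for antagonist activity at transient receptor potential cation channel subfamily V member 1 (Rattus norvegicus) (a lower number here means a stronger inhibitor, a higher number a weaker inhibitor), compound 1 gives 17.3 nM
- Compound 2 `CCCCc1ccc(NC(=O)N2CCN(c3ncccc3Cl)CC2)cc1`: in this assay compound 2 gives 203 nM
- Compound 3 `O=C(Nc1ccc(OC(F)(F)F)cc1)N1CCN(c2ncccc2Cl)CC1`: in this assay compound 3 gives 261 nM

Compound 3 stands at the highest number of the three. Its neighbour is compound 2, from which it is separated by a 1.3-fold higher number from compound 2 to compound 3 (0.11 log units; within the scatter), a gap within the scatter. The larger separation is a 15-fold higher number from compound 1 to compound 3 (1.18 log units; beyond the scatter), and the related step of a 12-fold higher number from compound 1 to compound 2 (1.07 log units; beyond the scatter) is of similar size, so the isopropyl compound stands clearly apart while the butyl and trifluoromethoxy compounds sit together.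

Compound 4 `O=C(Nc1ccc(Cl)cc1)N1CCN(c2ncccc2Cl)CC1` is made from compound 3 by one change: chloro in place of trifluoromethoxy on an aromatic carbon. Among the measured compounds shown here, none of the measured steps involves chloro, so no step bears directly on this change. The measured steps only show that the group on that aromatic carbon can shift the number by a large amount, and that two different groups gave close numbers. With nothing to anchor a direction, the expectation is a modest movement of a 2.9-fold lower number from compound 3 to compound 4 (0.46 log units; beyond the scatter) toward a lower number, with wide uncertainty. Compound 4 is therefore estimated at 90 nM, within a range from 20 nM to 400 nM in this assay.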

Compound 4, half-maximal inhibitory concentration: 2670 nM
Beside the measured number, compound 4's estimate is 30-fold (1.47 log units) below it, and the stated range ends below it.
By their numbers in this assay, from the lowest: compound 1; then compounds 2 and 3 (each within the scatter of the next); then compound 4.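

In this assay the step of a 10-fold higher number from compound 3 to compound 4 (1.01 log units; beyond the scatter) is large, so this position does not tolerate every swap equally: exchanging trifluoromethoxy for a lone chloro atom on this aromatic carbon weakens inhibition clearly, whereas the butyl and trifluoromethoxy compounds had landed within the scatter of each other. The chloro compound also stands apart from the other two, with the step of a 13-fold higher number from compound 2 to compound 4 (1.12 log units; beyond the scatter) and the much wider step a 150-fold higher number from compound 1 to compound 4 (2.19 log units; beyond the scatter) both beyond the scatter, which makes compound 4 the weakest inhibitor of the four and shows that this single substituent can span a very wide range of potency while the rest of the molecule stays the same. Nothing available here explains why chloro gives so much weaker inhibition than the other three groups.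

As far as these compounds go, it remains open whether another small group, such as fluoro or methyl, would fall near chloro or nearer the others. From the compounds shown here alone, it is equally open whether a more branched group such as tert-butyl would match or pass the isopropyl group of compound 1.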